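The source may report more compounds than this note shows. Statements on the series, on what has been measured and on what is new or still open speak of the compounds shown alone.

- Compound 1 `CCCn1c(=O)n(CC(=O)O)c(=O)c2[nH]cnc21`: 41000 nM
- Compound 2 `CCCn1c(=O)n(CCC(N)=O)c(=O)c2[nH]cnc21`: 13100 nM
- Compound 3 `CCCn1c(=O)n(C)c(=O)c2[nH]cnc21`: 1600 nM

In a functional assay (trachea) with Cavia porcellus as the target (a lower number here means that less compound is needed, a higher number that more compound is needed for the effect), compound 3 has the lowest number of the three at 1600 nM. Compound 4 `CCCn1c(=O)n(C)c(=O)c2c1ncn2CCC#N` has not yet been measured. It differs from compound 3 by one change, 2-cyanoethyl in place of hydrogen on an aromatic nitrogen.

Within the data shown here, no measured step involves this change, so the evidence is only indirect. The three measured compounds differ at a saturated chain carbon bound to an aromatic nitrogen, and hydrogen there gave a 26-fold lower number from compound 1 to compound 3 (1.41 log units; beyond the scatter) and an 8.2-fold lower number from compound 2 to compound 3 (0.91 log units; beyond the scatter). The remaining step, a 3.1-fold lower number from compound 1 to compound 2 (0.50 log units; beyond the scatter), shows that the outcome depends on the group involved. In compound 1 and compound 2, the larger chains came with higher numbers than in compound 3, but the data do not show whether this carries over to a different nitrogen. A modest step towards a higher number is therefore expected in this assay, smaller than a 26-fold lower number from compound 1 to compound 3 (1.41 log units; beyond the scatter), although a step within the scatter remains possible. The estimate for compound 4 is 4000 nM, with an expected range from 1000 nM to 16000 nM. The estimated change is a 2.5-fold higher number from compound 3 to compound 4 (0.40 log units; beyond the scatter).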

Compound 4, half-maximal effective concentration: 27600 nM
The estimate for compound 4 lay 6.9-fold (0.84 log units) below the measured number; the measured number lies above the stated range.
By their numbers in this assay, from the lowest: compound 3; then compound 2; then compounds 4 and 1 (each within the scatter of the next).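

The three earlier compounds all keep hydrogen on the aromatic nitrogen of the five-membered aromatic ring and differ only in a chain on another nitrogen, so they could say nothing about this place. In this assay, 2-cyanoethyl in place of hydrogen on this nitrogen gives a 17-fold higher number from compound 3 to compound 4 (1.24 log units; beyond the scatter), which shows that this ring nitrogen is itself sensitive to substitution. A single change here, with the rest of the molecule kept, is enough for a large step towards needing more compound, and nothing in the data shown accounts for why the number rises.

Going by these compounds, whether the step belongs to the nitrile or to the chain that carries it remains open, and a plain propyl chain on the same nitrogen would separate the two. How an amine, a carboxylic acid or a longer chain would behave at this place is also unknown, as is whether a group smaller than 2-cyanoethyl would leave the number close to that of compound 3.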